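Mirror-image ring system with a protected amine chain

This account rests on a few compounds, and the source may have more. Where it says the series, first, only, none or still open, it means among the compounds named here.

Measured compounds:
- compound 1, `C[C@H]1N=C2C[C@H]3C[C@H](C3(C)C)[C@@]2(C)OC1=O`: 27000 nM
- compound 2, `CC(C)(C)OC(=O)NCCC[C@@H]1N=C2C[C@@H]3C[C@@H](C3(C)C)[C@]2(C)OC1=O`: 4100 nM
- compound 3, `CC(C)(C)OC(=O)NCCCC[C@H]1N=C2C[C@H]3C[C@H](C3(C)C)[C@@]2(C)OC1=O`: 14500 nM

These three compounds were tested in a functional assay on EL4 cells (Mus musculus) for antiproliferative activity, read by sulforhodamine B assay, with a stated time of 48 h; a higher number here means a weaker inhibitor, a lower number a stronger inhibitor. Compound 3 stands second highest of the three numbers. Its nearest neighbour is compound 1, whose number is higher but within the usual scatter, so the two cannot be told apart. Compound 2 lies furthest away, with a lower number beyond the scatter.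

Compound 4, `CC(C)(C)OC(=O)NCCCC[C@@H]1N=C2C[C@@H]3C[C@@H](C3(C)C)[C@]2(C)OC1=O`, has not yet been measured. It differs from compound 3 as follows: the two compounds have the same atoms and bonds and differ only in configuration as drawn: 4 of 4 stereo elements differ (all stereocentres are inverted: mirror images); a stereocentre at a saturated ring carbon is drawn R in compound 3 and S in compound 4; a stereocentre at a saturated ring carbon is drawn R in compound 3 and S in compound 4; a stereocentre at a saturated ring carbon is drawn R in compound 3 and S in compound 4; a stereocentre at a saturated ring carbon is drawn R in compound 3 and S in compound 4. Compound 2 is drawn with the same configuration as compound 4, and it gives the lowest number of the three. On that basis a step toward a lower number is expected, from compound 3 to compound 4 of about a 2.4-fold lower number from compound 3 to compound 4 (0.38 log units; beyond the scatter), because compound 2 gives 4100 nM in this assay. Compound 4 is therefore estimated at 6000 nM, with a range from 2500 nM to 15000 nM.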

Compound 4, half-maximal inhibitory concentration: 15000 nM
Beside the measured number, compound 4's estimate is 2.5-fold (0.40 log units) below it; the measured number falls inside the stated range.
By their numbers in this assay, from the lowest: compound 2; then compounds 3, 4 and 1 (each within the scatter of the next).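

In this assay, the mirror-image pair gives a 1.0-fold higher number from compound 3 to compound 4 (0.01 log units; within the scatter), so inverting all four stereocentres leaves no readable difference for this chain. The comparison tests configuration alone, as nothing else separates the pair: the fact that compounds 3 and 4 differ only in the configuration as drawn. Between two compounds drawn with the same configuration, ((tert-butoxycarbonyl)amino)methyl in place of (tert-butoxycarbonyl)amino gives a 3.7-fold higher number from compound 2 to compound 4 (0.56 log units; beyond the scatter), so here the chain change produces a step beyond the scatter, while the inversion of configuration does not.

On these data alone, this finding rests on a single mirror-image pair, so whether other chain lengths would also be insensitive to configuration remains open. As far as these compounds go, it is also open how a free amine in place of the protected amine, or a longer chain, would read in this assay.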